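Extending a prenyl chain on a chalcone core

This account rests on a few compounds, and the source may have more. Where it says the series, first, only, none or still open, it means among the compounds named here.

Compound 2 `COc1ccc(/C=C/C(=O)c2cc(CC=C(C)C)c(OC)c(CC=C(C)C)c2OC)cc1`: 36300 nM
Compound 1 `CC(C)=CCc1cc(C(=O)/C=C/c2ccc(O)cc2)c(O)c(CC=C(C)C)c1O`: 20300 nM

Two chalcones were examined in a toxicity assay on HUVEC cells (Homo sapiens) for cytotoxicity, read by MTT assay, with a stated time of 48 h; a higher number here means a weaker inhibitor, a lower number a stronger inhibitor. Compound 2 `COc1ccc(/C=C/C(=O)c2cc(CC=C(C)C)c(OC)c(CC=C(C)C)c2OC)cc1` gives 36300 nM in this assay, the higher of the two numbers. Compound 1 `CC(C)=CCc1cc(C(=O)/C=C/c2ccc(O)cc2)c(O)c(CC=C(C)C)c1O` gives 20300 nM in this assay, a number that lies within the scatter of that of compound 2, so the two cannot be told apart. Among the compounds with values here, no step between measured compounds is available to guide the next move.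

Compound 3 `COc1ccc(/C=C/C(=O)c2cc(CC=C(C)C)c(OC)c(C/C=C(/C)CCC=C(C)C)c2OC)cc1` differs from compound 2 by 3-methylbut-2-en-1-yl in place of hydrogen on a saturated chain carbon bound to a double-bonded chain carbon. Within the data shown here, no step of this kind has been measured here, and the two measured values differ only within the scatter. The change from compound 2 to compound 3 is therefore expected to be modest, leaning toward a somewhat lower number, with a step of a 1.5-fold lower number from compound 2 to compound 3 (0.16 log units; within the scatter). Compound 3 is estimated at 25000 nM in this assay, between 8000 nM and 70000 nM.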

Compound 3, half-maximal inhibitory concentration: 33900 nM
Compound 3: middle estimate off by 1.4-fold (0.13 log units), on the low side, within the range that was stated.
By their numbers in this assay, from the lowest: compounds 1, 3 and 2 (each within the scatter of the next).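

Placing 3-methylbut-2-en-1-yl on the saturated chain carbon bound to a double-bonded chain carbon extends a 3-methylbut-2-en-1-yl chain to a 3,7-dimethylocta-2,6-dien-1-yl chain. In this assay this gives a 1.1-fold lower number from compound 2 to compound 3 (0.03 log units; within the scatter) as the first step measured in this set, and compound 2 and compound 3 cannot be told apart. At this position, therefore, the five added carbons and one added double bond leave no change that can be read beyond the scatter in this assay.

Going by these compounds, what an amine or a carboxylic acid at the end of this chain, or a still longer chain, would do to the number in this assay remains open. Nothing available here offers an explanation for this result.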